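Substituent at the nitro-bearing carbon: compound 4 forecast

The compounds below may be only part of what the source reports. "The series", "measured", "known", "first", "only" and "open" are said of these compounds alone.

Working notes on the series around the shared core of compound 1 `COc1cc[nH]c1/C=C1\C(=O)Nc2ccc([N+](=O)[O-])c(N3CCC(O)CC3)c21`. In a functional assay on RKO cells (Homo sapiens) for antiproliferative activity, read by MTT assay, with a stated time of 5 days (a higher number here means a weaker inhibitor, a lower number a stronger inhibitor), compound 1 gives < 10 nM, which is a limit of the assay rather than a number (the limit of < 10 nM in this assay, at which 1 of the 3 values shown sits). Compound 2 `COc1cc[nH]c1/C=C1\C(=O)Nc2ccc([N+](=O)[O-])c(N[C@H]3CC[C@H](O)C3)c21` gives 339 nM in this assay, and compound 3 `COc1cc[nH]c1/C=C1\C(=O)Nc2ccc([N+](=O)[O-])c(-n3ccnc3)c21` gives 3920 nM. Compound 3 thus sits highest of the two numbers recorded, with compound 2 nearest; the step of a 12-fold higher number from compound 2 to compound 3 (1.06 log units; beyond the scatter), and the step of an at least 390-fold higher number from compound 1 to compound 3 (2.59 log units; beyond the scatter). Compound 1 to compound 2 also moves upward: an at least 33-fold higher number from compound 1 to compound 2 (1.53 log units; beyond the scatter).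

Compound 4 `COc1cc[nH]c1/C=C1\C(=O)Nc2ccc([N+](=O)[O-])c(N3CCCC(CO)C3)c21` is not yet measured in this assay. Its change from compound 3 is 3-(hydroxymethyl)piperidin-1-yl in place of 1H-imidazol-1-yl on an aromatic carbon. The incoming group is a six-membered non-aromatic ring with one hetero atom bearing a hydroxymethyl group, closer in kind to the 4-hydroxypiperidin-1-yl of compound 1 than to the imidazolyl of compound 3. Among the compounds with values here, the steps that bear on it are those from compound 1 and compound 2 to compound 3, both large and upward; the return is expected to run the other way. The expected step is a 200-fold lower number from compound 3 to compound 4 (2.29 log units; beyond the scatter), a large fall in the number. Compound 4 is therefore estimated at 20 nM, within a range of 5 nM to 100 nM, with some chance that only a limit is reported.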

Compound 4, half-maximal inhibitory concentration: 124 nM
Compound 4: the middle estimate sits 6.2-fold (0.79 log units) below what was measured; the whole stated range lies below it.
By their numbers in this assay, from the lowest: compound 4; then compound 2; then compound 3. At a limit, below all of these: compound 1.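

In this assay, 3-(hydroxymethyl)piperidin-1-yl in place of 1H-imidazol-1-yl on this aromatic carbon, ortho to a nitro group, gives a 32-fold lower number from compound 3 to compound 4 (1.50 log units; beyond the scatter), and in place of (3-hydroxycyclopentyl)amino it gives a 2.7-fold lower number from compound 2 to compound 4 (0.44 log units; beyond the scatter), so a six-membered non-aromatic ring group need not match the result of compound 1 even when it carries a hydroxyl. Within the data shown here, the two groups built on that ring are clearly separated at this position, with an at least 12-fold higher number from compound 1 to compound 4 (1.09 log units; beyond the scatter), and this is the first step between two groups of that kind. The value of compound 1 is a limit and not a number, so that step gives only a bound on the gap: the limit of < 10 nM in this assay, at which 1 of the 4 values shown sits.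

The compounds shown do not separate the place of the substituent on the ring from the change of hydroxy to hydroxymethyl, which a 4-(hydroxymethyl)piperidin-1-yl or a 3-hydroxypiperidin-1-yl group would address. Also open, from the compounds shown here alone, is how a plain piperidin-1-yl group without a hydroxyl, or a morpholin-4-yl group, would read at this carbon.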